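The source may report more compounds than this note shows. Statements on the series, on what has been measured and on what is new or still open speak of the compounds shown alone.

Working notes on the series. The shared core of compound 1, `CN1CCN(c2nc3ccccc3[nH]2)CC1`, carries a 4-methylpiperazin-1-yl group and a bare aromatic nitrogen. In a functional assay on ileum for inhibition of histamine H1 receptor (Cavia porcellus) (a lower number here means a stronger inhibitor, a higher number a weaker inhibitor), compound 1 gives only a limit of the assay, > 3000 nM, not a number. Within the data shown here, this is the sole compound at the limit of > 3000 nM in this assay, at which 1 of the 3 values shown sits. The two other compounds shown both carry a group on the aromatic nitrogen of the core and a longer chain on the second ring: compound 2, `CCCCN1CCN(c2nc3ccccc3n2CCOCC)CC1`, gives 15 nM in this assay, and compound 3, `CCCCCN1CCCN(c2nc3ccccc3n2CCOCC)CC1`, gives 7.4 nM. No pair among these three differs in one place only, so no single measured step exists; the two substituted compounds and the unsubstituted one are merely seen side by side.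

Compound 4, `CCCSCn1c(N2CCN(C)CC2)nc2ccccc21`, is built from compound 1 by the change ((propylsulfanyl)methyl in place of hydrogen on an aromatic nitrogen). The only measured signal is that compound 1 sits at the limit while compounds 2 and 3, each with an occupied aromatic nitrogen, sit low in this assay. A large step toward a stronger inhibitor is therefore expected, well beyond the scatter, from compound 1 to compound 4: the expected step is an at least 25-fold lower number from compound 1 to compound 4 (1.39 log units; beyond the scatter). The estimate for compound 4 stays short of compound 2 and compound 3. For compound 4 the value in this assay is estimated at 120 nM, with a range from 20 nM to 900 nM.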

Compound 4, half-maximal inhibitory concentration: 68 nM
For compound 4 the middle estimate is 1.8-fold (0.25 log units) above the measured one, and the stated range covers the measured number.
By their numbers in this assay, from the lowest: compound 3; then compound 2; then compound 4. At a limit, above all of these: compound 1.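

With the 4-methylpiperazin-1-yl group unchanged, this assay now has its first step in one place on this aromatic nitrogen: (propylsulfanyl)methyl in place of hydrogen gives an at least 44-fold lower number from compound 1 to compound 4 (1.64 log units; beyond the scatter). Compounds 2 and 3 each differ from compound 1 in more than one place, so they could not separate the aromatic nitrogen from the second ring, whereas compound 4 shows that filling this nitrogen alone, with no longer chain on the second ring, is enough to reach a measured number. On these data alone, the true size of this step stays unknown because compound 1 gives only a limit of the assay: the limit of > 3000 nM in this assay, at which 1 of the 4 values shown sits.

As far as these compounds go, whether a plain pentyl chain, an amine or a carboxylic acid on this aromatic nitrogen would give a step of similar size remains open, and with it whether the sulfur of the (propylsulfanyl)methyl group matters at all. Also open, from the compounds shown here alone, is what a longer chain on the second ring would do in this assay when combined with (propylsulfanyl)methyl on the aromatic nitrogen.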